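A few compounds are considered here, and "the series" means these few. Any claim that something is new, unique, unknown or untested is made for them only; others in the source may bear on it.

Working notes on the series. Compound 1 `CC(Cc1ccc(NCc2cccc(Oc3ccccc3)c2)cc1)C(=O)O` and compound 2 `CNC(=O)CCc1ccc(NCc2cccc(Oc3ccccc3)c2)cc1` share one core and differ in a single place, the group on a saturated chain carbon bound to an aromatic carbon. In a functional assay on CHO cells for agonist activity at Free fatty acid receptor 1 (Homo sapiens), read by a luciferase reporter (on this read-out higher numbers stand for larger maximal responses and lower numbers for smaller maximal responses), compound 1 gives 70% and compound 2 gives 67%. Compound 2 stands as the lower of the two numbers, yet the step of a number 3 percentage points lower from compound 1 to compound 2 (within the scatter) shows that both lie within the scatter of each other. Compound 3 `CN(C)C(=O)CCc1ccc(NCc2cccc(Oc3ccccc3)c2)cc1` carries methyl in place of hydrogen on an amide-type nitrogen. For the measured compounds named here, the only measured step that bears on it is the exchange from compound 1 to compound 2, which replaced the whole group on that chain carbon and stayed within the scatter; no measured step touches the amide-type nitrogen itself. The expectation for compound 3 in this assay is therefore no step beyond the scatter, a number 5 percentage points lower from compound 2 to compound 3 (within the scatter). Compound 3 is thus estimated to give 62% in this assay, with a range from 40% to 82%.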

Compound 3, largest response reached (reported as percent of maximum), in percent of the reference or control that the assay uses: 50%
Compound 3: middle estimate off by 12 percentage points, on the high side; measured number inside the range.
By their numbers in this assay, from the lowest: compound 3; then compounds 2 and 1 (each within the scatter of the next).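

In this assay, the amide-type nitrogen proves to be a place where one added methyl counts: methyl in place of hydrogen there gives a number 17 percentage points lower from compound 2 to compound 3 (beyond the scatter) and carries the series beyond the scatter, which the earlier exchange of the whole group on the chain carbon did not do. With (dimethylcarbamoyl)methyl in place of 1-carboxyethyl, the comparison gives a number 20 percentage points lower from compound 1 to compound 3 (beyond the scatter), so the dimethylcarbamoyl form separates from compound 1 where the methylcarbamoyl form of compound 2 did not. Nothing available explains the lower maximal response of compound 3.

Open, going by these compounds, is whether the primary carboxamide would read with compound 2 or with compound 3. Also open, on these data alone, is whether a longer chain on the amide nitrogen, such as ethyl, or a pyrrolidine amide would lower the response further or restore it.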